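Working notes on compound 3: methyl in place of methoxy

This account rests on a few compounds, and the source may have more. Where it says the series, first, only, none or still open, it means among the compounds named here.

Measured so far:
compound 1 `COc1ccc(OC(=O)Nc2ccc([Se]C#N)cc2)cc1`: 44600 nM
compound 2 `CC(C)COC(=O)Nc1ccc([Se]C#N)cc1`: 47300 nM

Of the compounds shown here, two have been measured in a functional assay on PC-3 cells (Homo sapiens) for cytotoxicity, read by MTT assay, with a stated time of 72 h; on this read-out lower numbers stand for stronger inhibition of growth and higher numbers for weaker inhibition of growth. Compound 1 gives 44600 nM, the lower of the two numbers, and compound 2 gives 47300 nM; the gap between them lies within the scatter, so neither is set apart from the other.

Compound 3 `Cc1ccc(OC(=O)Nc2ccc([Se]C#N)cc2)cc1` is not yet measured. It differs from compound 1 in one place: methyl in place of methoxy on an aromatic carbon. Among the measured compounds shown here, no step between measured compounds matches this change, so there is nothing to set its size. Both measured numbers sit close together, and a small substituent swap of this kind is expected to move the read-out little, if at all, in this assay. Compound 3 is therefore expected at 45000 nM, between 20000 nM and 100000 nM. The step from compound 1 to compound 3 is expected to be a 1.0-fold higher number from compound 1 to compound 3 (0.00 log units; within the scatter), no further than the scatter.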

Compound 3, concentration for total growth inhibition: 32300 nM
Compound 3: the middle estimate sits 1.4-fold (0.14 log units) above what was measured; measured number inside the range.
By their numbers in this assay, from the lowest: compounds 3, 1 and 2 (each within the scatter of the next).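

In this assay, methyl in place of methoxy on an aromatic carbon, para to a large group, gives a 1.4-fold lower number from compound 1 to compound 3 (0.14 log units; within the scatter) and so does not set the two compounds apart. Among the compounds shown here, this is the first single-place step, and it shows that this position accepts the loss of the methoxy oxygen, with its hydrogen-bond acceptor, without a change beyond the scatter. Nothing available explains this result or bears on the role of either group.

With only methoxy and methyl compared here, the step says little about how far the read-out can move at this position. As far as these compounds go, whether an amine, a carboxylic acid or a longer chain on the same aromatic carbon would give a step beyond the scatter remains open.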